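The compounds below may be only part of what the source reports. "The series", "measured", "known", "first", "only" and "open" are said of these compounds alone.

The measured compounds and their values:
compound 1 `O=C(NCC1CCN(CCCS(=O)(=O)N2CCN(Cc3cccnc3)CC2)CC1)c1cccc2c1OCCO2`: 0.159 nM
compound 2 `O=C(NCC1CCN(CCCS(=O)(=O)N2CCOCC2)CC1)c1cccc2c1OCCO2`: 0.398 nM

In an assay on isolated protein for inhibition of 5-hydroxytryptamine receptor 4 (Homo sapiens) (on this read-out lower numbers stand for stronger inhibition and higher numbers for weaker inhibition), compound 1 gives 0.159 nM, the lowest of the two numbers. Compound 2 gives 0.398 nM in this assay, and the gap between the two lies beyond the scatter. Compound 3 `O=C(NCC1CCN(CCCS(=O)(=O)N2CCN(S(=O)(=O)c3ccc(F)cc3)CC2)CC1)c1cccc2c1OCCO2` is not yet measured and differs from compound 1 in one place: (4-fluorophenyl)sulfonyl in place of (pyridin-3-yl)methyl on an amine nitrogen in a ring. For the measured compounds named here, no measured pair shows this kind of change, so the expected step of a 3.1-fold higher number from compound 1 to compound 3 (0.50 log units; beyond the scatter) is a modest weakening, near the edge of the scatter. Compound 3 is estimated at 0.5 nM, within a range from 0.15 nM to 2 nM.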

Compound 3, inhibition constant: 0.0316 nM
Estimate against measurement, compound 3: 16-fold (1.20 log units) above; measured number below the stated range.
By their numbers in this assay, from the lowest: compound 3; then compound 1; then compound 2.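

In this assay, the amine nitrogen in the ring carries a larger group without any loss: (4-fluorophenyl)sulfonyl in place of (pyridin-3-yl)methyl gives a 5.0-fold lower number from compound 1 to compound 3 (0.70 log units; beyond the scatter). This single pair shows that the number at this position responds to the group placed there, and that a sulfonyl-linked ring can read lower than a pyridinylmethyl one. No measurement at hand accounts for the change. From the compounds shown here alone, it remains open whether the sulfonyl link or the fluorine-bearing ring carries the step, and how an unsubstituted phenylsulfonyl, a methanesulfonyl or a benzoyl group would read on this nitrogen.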